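Thiazolidinedione aryl ethers: towards a carbocyclic ether partner

The source may hold more compounds than are shown below. What is called first, only, known or untested is meant among the compounds shown, and "the series" means these compounds.

Measured so far:
compound 1 `O=C1NC(=O)C(Cc2ccc(Oc3ccc(C(F)(F)F)cn3)cc2)S1` — 558 nM
compound 2 `O=C1NC(=O)C(Cc2ccc(Oc3ccc(Cl)cn3)cc2)S1` — 1870 nM

Within the data shown here, only two compounds carry numbers in a functional assay for agonist activity at Free fatty acid receptor 1 (Homo sapiens), read by FLIPR, in the presence of a further agent that is not named here; on this read-out lower numbers stand for an effect already at smaller amounts and higher numbers for an effect only at larger amounts of compound. Among the measured compounds shown here, compound 1 gives 558 nM; compound 2 gives 1870 nM, the higher of the two, with the single measured step of a 3.4-fold higher number from compound 1 to compound 2 (0.53 log units; beyond the scatter) separating it from compound 1. For the measured compounds named here, that step concerns chloro in place of trifluoromethyl on an aromatic carbon and is the only information on how this series responds to a change at the ether partner.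

Compound 3 `Cc1ccccc1Oc1ccc(CC2SC(=O)NC2=O)cc1` is not yet measured. Relative to compound 2 the change is 2-methylphenyl in place of 5-chloropyridin-2-yl on an oxygen on an aromatic ring. Going by the values given here, no measured step covers an exchange of the whole ring at the ether oxygen, so the step from compound 1 to compound 2 bears on it only loosely: it shows that a modest alteration of the ring's substituent already moves the read-out beyond the scatter, while saying nothing about replacing the ring itself. The step from compound 2 is therefore estimated at a 1.1-fold higher number from compound 2 to compound 3 (0.03 log units; within the scatter). A modest step in either sense would be unsurprising, and a value close to that of compound 2 is taken as the middle of a wide range. Compound 3 is expected to give 2000 nM in this assay, between 600 nM and 7000 nM.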

Compound 3, half-maximal effective concentration: 124 nM
Beside the measured number, compound 3's estimate is 16-fold (1.21 log units) above it; measured number below the stated range.
By their numbers in this assay, from the lowest: compound 3; then compound 1; then compound 2.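

The ring on the oxygen is a far more sensitive point than the substituent change alone suggested: 2-methylphenyl in place of 5-chloropyridin-2-yl gives a 15-fold lower number from compound 2 to compound 3 (1.18 log units; beyond the scatter) in this assay, a large step, while chloro in place of trifluoromethyl gave only a 3.4-fold higher number from compound 1 to compound 2 (0.53 log units; beyond the scatter), a modest one in the opposite sense. A six-membered aromatic ring of carbon only therefore serves as the ether partner, and compound 3 at 124 nM now has the lowest number of the three, with compound 1 at 558 nM next, so the pyridine ring of compound 1 and compound 2 is not needed for activity in this range. Nothing measured on these compounds explains the step.

The step changes the ring atoms, removes chloro and adds methyl all at once, so the compounds shown do not divide the gain among these changes. Unsubstituted phenyl, 2-chlorophenyl and a pyridine ring carrying methyl would separate them, and a group larger than methyl, such as ethyl or methoxy, would test how much room the ring's substituent has.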